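The source may hold more compounds than are shown below. What is called first, only, known or untested is meant among the compounds shown, and "the series" means these compounds.

Measured so far:
- compound 1 `CO[C@H]1O[C@H](COc2ccc3c(c2)CCCC3)[C@@H](O)[C@H](O)[C@H]1Oc1ccc(OC2CCCCC2)cc1`: 17000 nM
- compound 2 `CO[C@@H]1O[C@H](COc2ccc3c(c2)CCCC3)[C@@H](O)[C@H](O)[C@H]1Oc1ccc(OC2CCCCC2)cc1`: "not determined" (no result reported)

In a functional assay on MCF7 cells (Homo sapiens) for cytotoxicity, read by MTT assay, with a stated time of 48 h (a higher number here means that more compound is needed for the effect, a lower number that less compound is needed), compound 1 gives 17000 nM. Compound 2 has no number in this assay; what is known of it is the fact that compounds 1 and 2 differ only in the configuration as drawn, so compound 1 is the only measured point of reference for the series.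

Compound 3 `CO[C@@H]1O[C@H](COc2ccc(-c3ccccc3)cc2)[C@@H](O)[C@H](O)[C@H]1Oc1ccc(OC2CCCCC2)cc1` is not yet measured. It differs from compound 2 by 4-phenylphenyl in place of 1,2,3,4-tetrahydronaphthalen-6-yl on an oxygen on a saturated carbon. Within the data shown here, no measured step of this kind exists, so there is no basis for a direction; the change is expected to stay within the scatter in this assay, or at most a small shift either way.

Compound 3 is therefore estimated at about 15000 nM in this assay, with a range from 4000 nM to 60000 nM, the range kept wide since compound 2 itself has no number.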

Compound 3, half-maximal effective concentration: 18000 nM
Compound 3: middle estimate off by 1.2-fold (0.08 log units), on the low side, and the stated range covers the measured number.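

Among these compounds, compound 2 has no number to set against compound 3, so no step from compound 2 to compound 3 can be read. Still open are the effect of 4-phenylphenyl in place of 1,2,3,4-tetrahydronaphthalen-6-yl on its own and the effect of configuration, for which only one side has a value: the fact that compounds 1 and 2 differ only in the configuration as drawn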